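Free aniline series: fluoro to methyl on the pendant phenyl

The source may report more compounds than this note shows. Statements on the series, on what has been measured and on what is new or still open speak of the compounds shown alone.

Compound 2 `Nc1cccc(-c2cn3nc(-c4ccc(F)cc4)sc3n2)c1` is the free aniline carrying a 4-fluorophenyl on the shared core. In a functional assay on FM3A cells (Mus musculus) for inhibition, read by cell counting, with a stated time of 2 days (on this read-out lower numbers stand for stronger inhibition and higher numbers for weaker inhibition), compound 2 gives 33000 nM, the highest number of the three measured. Its acylated partner compound 3 `C=C(Br)C(=O)Nc1cccc(-c2cn3nc(-c4ccc(F)cc4)sc3n2)c1` gives 610 nM in this assay, and the step of a 54-fold lower number from compound 2 to compound 3 (1.73 log units; beyond the scatter) shows that the acyl group, not the pendant aryl, carries the bulk of the measured change. Compound 1 `C=C(Br)C(=O)Nc1cccc(-c2cn3nc(Cc4cccc(OC)c4)sc3n2)c1` gives 1100 nM in this assay; the step of a 1.8-fold lower number from compound 1 to compound 3 (0.26 log units; within the scatter) indicates that swapping the aryl on the core, even 3-methoxybenzyl for 4-fluorophenyl, moves the number little.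

Compound 4 `Cc1ccc(-c2nn3cc(-c4cccc(N)c4)nc3s2)cc1` differs from compound 2 only in the aryl: methyl in place of fluoro on an aromatic carbon. Among the measured compounds shown here, no measured step tests this exact swap, and none tests an aryl change on the free aniline; the nearest guide is the aryl swap between compound 1 and compound 3, which stayed within the scatter. A small change in this assay, with no direction beyond the scatter, is therefore expected for compound 4, and the step of no change at the digits printed from compound 2 to compound 4 (within the scatter) is the estimate. Compound 4 is expected to give 33000 nM in this assay, within 12000 nM to 90000 nM.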

Compound 4, half-maximal inhibitory concentration: 5800 nM
The estimate for compound 4 lay 5.7-fold (0.76 log units) above the measured number; the whole stated range lies above it.
By their numbers in this assay, from the lowest: compounds 3 and 1 (each within the scatter of the next); then compound 4; then compound 2.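

Among the compounds shown here, on the free aniline, the position para to a large group on the pendant phenyl is not silent: in this assay the change from 4-fluorophenyl to 4-methylphenyl gives a step beyond the scatter (a 5.7-fold lower number from compound 2 to compound 4 (0.76 log units; beyond the scatter)), whereas the one earlier aryl change, made on the acylated compounds, stayed within it (a 1.8-fold lower number from compound 1 to compound 3 (0.26 log units; within the scatter)). The earlier reading that the aryl moves the number little therefore does not carry over to the free aniline, although this single pair is modest beside the large step from adding the (1-bromoethenyl)carbonyl group (a 54-fold lower number from compound 2 to compound 3 (1.73 log units; beyond the scatter)). Nothing measured here bears on why methyl and fluoro differ at this position.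

The compounds shown leave open whether methyl in place of fluoro moves the number in the same direction when the aniline nitrogen carries the (1-bromoethenyl)carbonyl group. They also leave open how other groups at this position, such as methoxy, an amine, a carboxylic acid or a longer alkyl chain, would compare with methyl and fluoro on the free aniline.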